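Shortening the alkene tail of a diyne alcohol

A few compounds are considered here, and "the series" means these few. Any claim that something is new, unique, unknown or untested is made for them only; others in the source may bear on it.

The compounds here share a long chain carrying two neighbouring triple bonds and ending in an alcohol; they were tested in a functional assay on SK-MEL-2 cells (Homo sapiens) for cytotoxicity; a lower number here means that less compound is needed, a higher number that more compound is needed for the effect. Compound 1, `C=CCCCCCCCC#CC#CCO`, gives 3.94 ug/mL in this assay. Compound 3, `C=CCCCCCCCC#CC#CC(O)CC(C)=O`, gives 3.52 ug/mL; the step of a 1.1-fold lower number from compound 1 to compound 3 (0.05 log units; within the scatter) lies within the scatter, so the two cannot be ranked. Compound 2, `C=CCCCCCCCC#CC#CCOCC(=O)OC`, reaches only the limit of the assay, > 30 ug/mL, and so has no number. For the measured compounds named here, of the two numbers known, compound 1 is the higher, with compound 3 the nearest to it.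

Compound 4, `C=CCCCCCC#CC#CCO`, differs from compound 1 by vinyl in place of but-3-en-1-yl on a saturated chain carbon, five bonds along the chain from a triple-bonded carbon. Neither measured step touches this part of the molecule: an at least 7.6-fold higher number from compound 1 to compound 2 (0.88 log units; beyond the scatter) changes the alcohol, and a 1.1-fold lower number from compound 1 to compound 3 (0.05 log units; within the scatter) adds a group next to the alcohol carbon. The chain length itself has not been varied among the measured compounds, so no direction can be read from them. The expectation for compound 4 is therefore a step of about a 1.3-fold higher number from compound 1 to compound 4 (0.10 log units; within the scatter), that is, no change beyond the scatter. Compound 4 is estimated at 5 ug/mL, within 2 ug/mL to 15 ug/mL.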

Compound 4, concentration for half-maximal effect: 9.56 ug/mL
The estimate for compound 4 lay 1.9-fold (0.28 log units) below the measured number; the measured number falls inside the stated range.
By their numbers in this assay, from the lowest: compounds 3 and 1 (each within the scatter of the next); then compound 4. At a limit, above all of these: compound 2.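

In this assay, putting vinyl in place of but-3-en-1-yl on a saturated chain carbon, five bonds along the chain from a triple-bonded carbon, gives a 2.4-fold higher number from compound 1 to compound 4 (0.38 log units; beyond the scatter) and so more compound is needed with the shorter tail. For the compounds shown here, the earlier steps changed only the alcohol end, so this is the first sign that the alkene tail also counts, though the direction rests on this single pair. The data shown offer no measurement that explains the rise.

From the compounds shown here alone, whether a longer chain would bring the number down, or a still shorter one would push it further up, stays open. So does the part played by the double bond itself, which a saturated tail such as butyl would test, and the effect of an amine in place of the alcohol.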